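Hydrogen in place of methyl on compound 1

The source may hold more compounds than are shown below. What is called first, only, known or untested is meant among the compounds shown, and "the series" means these compounds.

In an in vitro ADME assay on microsomes from liver (Homo sapiens) for metabolic stability (on this read-out higher numbers stand for fast clearance and lower numbers for slow clearance), compound 1 `Cc1ncc(Cc2nc(-c3nc(C(F)(F)F)n[nH]3)n3ccccc23)cn1` gives < 8 mL.min-1.g-1 as a limit and not a number. Compound 2 `NC(=O)c1n[nH]c(-c2nc(Cc3ccccc3F)c3ccccn23)n1` gives < 8 mL.min-1.g-1 which is likewise a limit. Compound 3 `Cc1ncc(Cc2nc(-c3nc(C(F)(F)F)n[nH]3)n3cccc(F)c23)cn1` gives < 8 mL.min-1.g-1 which is again a limit. The measured set therefore shows the limit of < 8 mL.min-1.g-1 in this assay, at which 3 of the 3 values shown sit, and offers no number to work from.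

Compound 4 `FC(F)(F)c1n[nH]c(-c2nc(Cc3cncnc3)c3ccccn23)n1` differs from compound 1 by hydrogen in place of methyl on an aromatic carbon so that 2-methylpyrimidin-5-yl becomes pyrimidin-5-yl. For the measured compounds named here, the only measured step from compound 1 is a step that the two limits leave unreadable from compound 1 to compound 3 with fluoro in place of hydrogen on an aromatic carbon, and it is a different change that gives no size to carry over.

No step beyond the usual scatter is expected, and no direction can be given, from the limit of compound 1 at < 8 mL.min-1.g-1 in this assay alone. The estimated step is a step that the limit leaves unreadable from compound 1 to compound 4 in plain expectation only. Compound 4 is estimated at 6 mL.min-1.g-1 with an expected range from 3 mL.min-1.g-1 to 12 mL.min-1.g-1.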

Compound 4, intrinsic clearance in microsomes: < 7 mL.min-1.g-1
Compound 4: only a limit was reported (the forecaster's own chance of this, stated with the estimate: 75%); the middle value lies beyond the limit too.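

In this assay compound 4 gives < 7 mL.min-1.g-1, which is a limit. Compound 1 gives < 8 mL.min-1.g-1, also a limit, so no step can be read between compound 1 and compound 4. The compounds shown leave open whether hydrogen in place of methyl changes clearance at all.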